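Trimethoxyphenyl for methoxyphenyl: an acylhydrazone step on HepG2

A few compounds are considered here, and "the series" means these few. Any claim that something is new, unique, unknown or untested is made for them only; others in the source may bear on it.

Three hydrazone carboxamides sharing one core were tested in a functional assay on HepG2 cells (Homo sapiens) for inhibition, read by MTT assay, with a stated time of 72 h; a higher number here means a weaker inhibitor, a lower number a stronger inhibitor. Compound 1, `COc1ccc(/C=N/NC(=O)c2sc(N(C)C(=O)NC(=O)c3c(F)cccc3F)nc2C)cc1`, gives 22.7 ug/mL. Compound 3, `CN(C(=O)NC(=O)c1c(F)cccc1F)c1nc(C(F)(F)F)c(C(=O)N/N=C/c2cccc(C(F)(F)F)c2)s1`, gives 27.9 ug/mL, and compound 2, `CN(C(=O)NC(=O)c1ccc([N+](=O)[O-])cc1)c1nc(C(F)(F)F)c(C(=O)N/N=C/c2ccc([N+](=O)[O-])cc2)s1`, gives 12.3 ug/mL. The number for compound 1 sits with that of compound 3 and that of compound 2 within the usual scatter, so the three cannot be told apart. Compound 4, `COc1cc(/C=N/NC(=O)c2sc(N(C)C(=O)NC(=O)c3c(F)cccc3F)nc2C)cc(OC)c1OC`, carries 3,4,5-trimethoxyphenyl in place of 4-methoxyphenyl on a carbon with a double bond to nitrogen. Going by the values given here, no pair of measured compounds shows this change, so nothing in the data fixes its size; the step from compound 1 to compound 4 in this assay is expected to stay within the scatter, as a 1.3-fold lower number from compound 1 to compound 4 (0.10 log units; within the scatter). Compound 4 is therefore estimated at 18 ug/mL, between 8 ug/mL and 40 ug/mL.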

Compound 4, half-maximal inhibitory concentration: > 100 ug/mL
Compound 4 was reported as a limit; the forecaster's own chance of this, stated with the estimate: 5%; middle value at least 5.5-fold (0.74 log units) from the limit.
By their numbers in this assay, from the lowest: compounds 2, 1 and 3 (each within the scatter of the next, the first and the last beyond it). At a limit, above all of these: compound 4.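

The earlier compounds shown here gave no step at this position, and here the group on the carbon with a double bond to nitrogen proves to matter: in this assay the change to 3,4,5-trimethoxyphenyl gives an at least 4.4-fold higher number from compound 1 to compound 4 (0.64 log units; beyond the scatter) in the shared core. Compound 4 gives > 100 ug/mL as a limit of the assay, not a number. On these data alone, the full size of the step therefore stays unknown: the limit of > 100 ug/mL in this assay, at which 1 of the 4 values shown sits.

The compounds shown leave open which of the added methoxy groups carries this step. They also leave open how a phenyl ring bearing a hydroxyl or an amine in place of the methoxy groups would read in this assay here.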